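A few compounds are considered here, and "the series" means these few. Any claim that something is new, unique, unknown or untested is made for them only; others in the source may bear on it.

Measured in a functional assay on MT4 cells (Homo sapiens) for cytotoxicity, read by MTT assay; a lower number here means that less compound is tolerated, a higher number that more compound is tolerated:
- Compound 1 `Cc1c(O)nc(Sc2ccccc2)nc1Cc1c(F)cccc1F`: > 72700 nM, a limit.
- Compound 2 `Cc1c(O)nc(Sc2ccc(Cl)cc2)nc1Cc1c(F)cccc1F`: > 66100 nM, a limit.
- Compound 3 `Cc1c(O)nc(Sc2ccccc2)nc1Cc1c(Cl)cccc1Cl`: > 66300 nM, a limit.

Going by the values given here, the series so far offers limits only, so compound 3 has no number to stand on and cannot be ranked against compound 1 or compound 2.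

The next compound is compound 4 `COc1ccc(Sc2nc(O)c(C)c(Cc3c(Cl)cccc3Cl)n2)cn1`, which keeps the core and the 2,6-dichlorophenyl group of compound 3. The change is 6-methoxypyridin-3-yl in place of phenyl on a sulfur.

Among the compounds with values here, two measured steps bear on this. The closer one is a step that the two limits leave unreadable from compound 1 to compound 2, since it also alters the phenyl on the sulfur, with chloro in place of hydrogen on an aromatic carbon. The other is a step that the two limits leave unreadable from compound 1 to compound 3, with 2,6-dichlorophenyl in place of 2,6-difluorophenyl. Neither has a readable size, and neither covers a pyridine ring or a methoxy group. They therefore give no ground for expecting a move in either direction in this assay.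

No shift beyond the scatter is expected, so the estimate is an at least 1.0-fold lower number from compound 3 to compound 4 (0.03 log units; that floor lies within the scatter). A limit is again the likeliest report. For compound 4 the estimated value is 61000 nM, with an expected range of 30000 nM to 80000 nM.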

Compound 4, half-maximal cytotoxic concentration: > 61300 nM
Compound 4 gave a limit, no number; the forecaster's own chance of this, stated with the estimate: 80%; middle value at least 1.0-fold (0.00 log units) away from the limit.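

In this assay compound 4 gives > 61300 nM, a limit. Compound 3 likewise has only a limit, so no step can be read between compound 3 and compound 4. The compounds shown leave open where any of the four would reach a measured half-maximal cytotoxic concentration, and whether 6-methoxypyridin-3-yl in place of phenyl changes it at all.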